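The compounds below may be only part of what the source reports. "The series", "measured", "known", "first", "only" and "open" are said of these compounds alone.

Compound 1 `Nc1nc(-c2ccc(Cl)cc2)c(CC(=O)O)s1` sits at the limit of > 100000 nM in an in vitro assay on HEK385-7 cells for displacement of a labelled ligand from prostaglandin D2 receptor 2 (Homo sapiens) (on this read-out lower numbers stand for stronger inhibition and higher numbers for weaker inhibition), a limit rather than a number. Compound 2 `O=C(O)Cc1sc(C(c2ccc(F)cc2)c2ccc(F)cc2)nc1-c1cc(F)cc(F)c1` gives 35 nM in this assay and so stands as the only number shown, the other value being (the limit of > 100000 nM in this assay, at which 1 of the 2 values shown sits). Compound 3 `NS(=O)(=O)c1ccc(-c2nc(C(c3ccc(F)cc3)c3ccc(F)cc3)sc2CC(=O)O)cc1` has not yet been measured and differs from compound 2 by 4-sulfamoylphenyl in place of 3,5-difluorophenyl on an aromatic carbon. Within the data shown here, no measured pair shows this change, so the numbers give no step to lean on. The step of a 2.9-fold higher number from compound 2 to compound 3 (0.46 log units; beyond the scatter) is expected to be a modest weakening, beyond the scatter only if at all. Compound 3 is therefore estimated at 100 nM, within a range from 20 nM to 600 nM.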

Compound 3, half-maximal inhibitory concentration: 1500 nM
Compound 3: the middle estimate sits 15-fold (1.18 log units) below what was measured; measured number above the stated range.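

The aromatic carbon next to the ring nitrogen is not indifferent to what it carries: in this assay, 4-sulfamoylphenyl in place of 3,5-difluorophenyl gives a 43-fold higher number from compound 2 to compound 3 (1.63 log units; beyond the scatter). This is the first single change shown at this position, and compound 3 still gives a measured number rather than a limit. Nothing shown accounts for the size of this step. The compounds shown leave open whether the step follows the entering sulfamoyl group or the leaving fluorines. A plain phenyl group or a 4-methylsulfonylphenyl group on this carbon would separate the two.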